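This account rests on a few compounds, and the source may have more. Where it says the series, first, only, none or still open, it means among the compounds named here.

Measured compounds in a functional assay for agonist activity at growth hormone secretagogue receptor type 1 (Homo sapiens), read by FLIPR; on this read-out lower numbers stand for smaller maximal responses and higher numbers for larger maximal responses:
- compound 1 `COc1ccc(F)c(-c2ccc(S(=O)(=O)Nc3cc(N4C[C@@H](C)N[C@@H](C)C4)ccc3OC)cc2)c1` gives 1.2
- compound 2 `COc1ccc(N2C[C@@H](C)N[C@@H](C)C2)cc1NS(=O)(=O)c1ccc(-c2cc(Cl)ccc2F)cc1` gives 1
- compound 3 `COc1ccc(N2C[C@@H](C)N[C@@H](C)C2)cc1NS(=O)(=O)c1ccc(-c2ccc(C)o2)cc1` gives 1

Compound 3 stands level with compound 2 at the digits shown, the two together the lowest of the three values; the only gap beyond the scatter is a number 0.20 lower from compound 1 to compound 3 (beyond the scatter), matched in size by a number 0.20 lower from compound 1 to compound 2 (beyond the scatter), while no change at the digits printed from compound 2 to compound 3 (within the scatter) is within the scatter.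

Compound 4 `COc1ccc(N2C[C@@H](C)N[C@@H](C)C2)cc1NS(=O)(=O)c1ccc(OCc2ccccc2)cc1` differs from compound 3 by benzyloxy in place of 5-methylfuran-2-yl on an aromatic carbon. For the measured compounds named here, the steps that bear on it are the two changes at the same aromatic carbon, each no more than modest, and the swap between two unlike groups there gave no change. A step of similar order or none beyond the scatter is therefore expected: no change at the digits printed from compound 3 to compound 4 (within the scatter).

Compound 4 is estimated at 1, within 0.8 to 1.2.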

Compound 4, intrinsic activity: the largest response reached, as a fraction of the reference agonist's: 0.8
Estimate against measurement, compound 4: 0.20 above; low and high end bracket the measured number.
By their numbers in this assay, from the lowest: compound 4; then compounds 2 and 3 (each within the scatter of the next); then compound 1.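

In this assay benzyloxy at this aromatic carbon breaks the level seen for the two previous replacements, with a number 0.20 lower from compound 3 to compound 4 (beyond the scatter) and a number 0.20 lower from compound 2 to compound 4 (beyond the scatter) both read here. The span across this carbon widens to a number 0.40 lower from compound 1 to compound 4 (beyond the scatter) and compound 4 is the lowest of the four, so the maximal response here depends on more than the aryl groups alone had shown. Nothing measured on these compounds accounts for the drop.

On these data alone, whether the step follows the oxygen link or the benzyl ring stays open. So does the response with a benzylamino group or a carboxylic acid at this carbon.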